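The source may hold more compounds than are shown below. What is called first, only, known or untested is meant among the compounds shown, and "the series" means these compounds.

In a functional assay for inhibition, with Rattus norvegicus as the target (on this read-out higher numbers stand for weaker inhibition and lower numbers for stronger inhibition), compound 2 `CC(C)(C)/N=c1\c(O)c(O)\c1=N/c1ccc(C#N)cc1` gives 560 nM and compound 3 `CCC(C)/N=c1\c(O)c(O)\c1=N/c1ccc(C#N)cc1` gives 2100 nM, the higher of the two single numbers and so the weaker inhibition. Swapping the group on the double-bonded nitrogen between these two produces a 3.8-fold higher number from compound 2 to compound 3 (0.57 log units; beyond the scatter). Compound 1 `C[C@@H](/N=c1\c(O)c(O)\c1=N/c1ccc(C#N)cc1)C(C)(C)C` gives 370 nM; 24300 nM (2 entries), two entries so far apart that they set no single level for comparison.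

Compound 4 `C[C@@H](/N=c1\c(O)c(O)\c1=N/c1ccc(C#N)cc1)c1ccccc1` keeps the shared core of compound 3 and carries 1-phenylethyl in place of sec-butyl on a double-bonded nitrogen. Going by the values given here, no measured step brings a ring into this place, so the sole guide is the modest step of a 3.8-fold higher number from compound 2 to compound 3 (0.57 log units; beyond the scatter), which shows that this group can shift the number to a limited degree. Among the compounds with values here, since compound 3 at 2100 nM sits at the high end of the single numbers, a modest move towards stronger inhibition is expected, though the direction is uncertain. The expected change is a 1.8-fold lower number from compound 3 to compound 4 (0.24 log units; within the scatter). For compound 4 the estimate is 1200 nM, with an expected range from 300 nM to 5000 nM.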

Compound 4, half-maximal inhibitory concentration: 56 nM
Compound 4: middle estimate off by 21-fold (1.33 log units), on the high side; the whole stated range lies above it.
By their numbers in this assay, from the lowest: compound 4; then compound 2; then compound 3.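

Going by these compounds alone, this place on the double-bonded nitrogen can move the number much further than the two alkyl groups suggested: in this assay, 1-phenylethyl gives a 38-fold lower number from compound 3 to compound 4 (1.57 log units; beyond the scatter), a larger move than the one between the alkyl groups, a 3.8-fold higher number from compound 2 to compound 3 (0.57 log units; beyond the scatter). The gain also holds against tert-butyl, with a 10-fold lower number from compound 2 to compound 4 (1.00 log units; beyond the scatter), so 1-phenylethyl gives stronger inhibition than either of these alkyl groups. Compound 4 is the only compound shown with a ring at this place, so the link between a ring and stronger inhibition rests on this single example.

Steps involving compound 1 cannot be read, so its tert-butyl-bearing group gives no clean comparison: the several entries of compound 1 in this assay, 370 nM; 24300 nM (2 entries) It remains open whether the aromatic ring itself matters or only the larger group, and how a cyclohexyl group or a chlorine-bearing phenyl ring would behave here.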